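Adding a second methoxy to compound 2

This account rests on a few compounds, and the source may have more. Where it says the series, first, only, none or still open, it means among the compounds named here.

In a functional assay on MOLT-4 cells (Homo sapiens) for antiproliferative activity, with a stated time of 48 h (a lower number here means a stronger inhibitor, a higher number a weaker inhibitor), compound 2 `C=C(Br)C(=O)Nc1ccc(C(=O)/C=C/c2cccc(OC)c2)cc1` gives 1100 nM and compound 1 `C=C(Br)C(=O)Nc1ccc(C(=O)/C=C/c2ccc(OC)cc2)cc1` gives 610 nM, a pair separated by a 1.8-fold higher number from compound 1 to compound 2 (0.26 log units; within the scatter). Compound 3 `C=C(Br)C(=O)Nc1ccc(C(=O)/C=C/c2ccccc2OC)cc1` gives 240 nM, apart from the others by a 4.6-fold lower number from compound 2 to compound 3 (0.66 log units; beyond the scatter) and a 2.5-fold lower number from compound 1 to compound 3 (0.41 log units; beyond the scatter). Compound 4 `C=C(Br)C(=O)Nc1ccc(C(=O)/C=C/c2ccc(OC)c(OC)c2)cc1` differs from compound 2 by methoxy in place of hydrogen on an aromatic carbon, ortho to a methoxy group. It thus carries the methoxy groups of compound 1 and compound 2 together, and the closest evidence is the small 1.8-fold higher number from compound 1 to compound 2 (0.26 log units; within the scatter). Among the measured compounds shown here, the larger steps involving compound 3 have no direct counterpart here. The expected change is a 1.5-fold lower number from compound 2 to compound 4 (0.17 log units; within the scatter), with no shift beyond the scatter anticipated. The estimate for compound 4 is 750 nM, within an expected range of 280 nM to 2000 nM.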

Compound 4, half-maximal inhibitory concentration: 1800 nM
Compound 4: the middle estimate sits 2.4-fold (0.38 log units) below what was measured, within the range that was stated.
By their numbers in this assay, from the lowest: compound 3; then compounds 1, 2 and 4 (each within the scatter of the next, the first and the last beyond it).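

Methoxy in place of hydrogen, ortho to a methoxy group, gives a 1.6-fold higher number from compound 2 to compound 4 (0.21 log units; within the scatter) in this assay and so does not separate the two compounds. Among the compounds shown here, the same change read from the other single-methoxy compound gives a 3.0-fold higher number from compound 1 to compound 4 (0.47 log units; beyond the scatter) and is the first step to show a second methoxy costing activity. No measurement shown explains this difference between the two steps.

Still open, on these data alone, is whether an amine or a hydroxyl in place of the added methoxy would read the same, and whether compound 3 would keep its stronger number with a second methoxy.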